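Thiocarbonate analogues probed against indoleamine 2,3-dioxygenase 1

The source may report more compounds than this note shows. Statements on the series, on what has been measured and on what is new or still open speak of the compounds shown alone.

Compound 1, `CC(C)(C)OC(=O)NCCOC(=O)SCc1ccccc1`, gives 3000 nM in an assay on isolated protein for inhibition of Indoleamine 2,3-dioxygenase 1 (Homo sapiens), with a stated time of 60 min; a lower number here means a stronger inhibitor, a higher number a weaker inhibitor.
Compound 2, `O=C(SCCc1ccc(O)cc1)SCc1ccc(Cl)cc1Cl`, gives 100 nM.
Compound 3, `O=C(SCCc1ccc(CO)cc1)SCc1ccc(Cl)cc1Cl`, gives 120 nM.

Among these three numbers compound 3 holds the second highest; its nearest neighbour is compound 2, within the scatter, and its furthest is compound 1, well beyond it. Compound 4, `COc1ccc(CCSC(=O)SCc2ccc(Cl)cc2Cl)cc1`, is not yet measured. It differs from compound 3 by methoxy in place of hydroxymethyl on an aromatic carbon. For the measured compounds named here, the only measured step that bears on this position is a 1.2-fold higher number from compound 2 to compound 3 (0.08 log units; within the scatter), which stayed within the scatter. A further exchange at the same place is therefore expected to move this assay only slightly, if at all. Compound 4 is expected to sit close to its parent, the step of a 1.3-fold higher number from compound 3 to compound 4 (0.12 log units; within the scatter) being small. The estimate for compound 4 is 160 nM, between 60 nM and 450 nM.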

Compound 4, half-maximal inhibitory concentration: 200 nM
The estimate for compound 4 lay 1.3-fold (0.10 log units) below the measured number; the range from low to high includes it.
By their numbers in this assay, from the lowest: compounds 2, 3 and 4 (each within the scatter of the next); then compound 1.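

With methoxy on this aromatic carbon, this assay shows a 1.7-fold higher number from compound 3 to compound 4 (0.22 log units; within the scatter) and a 2.0-fold higher number from compound 2 to compound 4 (0.30 log units; within the scatter) and thus hydroxy, hydroxymethyl and methoxy cannot be told apart here. Methoxy has no hydrogen-bond donor where hydroxymethyl has one, so among these compounds a donor at this place is not required to keep the number in this range. Nothing available bears on why these groups read alike. Going by these compounds, whether an amine, a carboxylic acid or a longer chain on the same carbon would also stay within the scatter remains open.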